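Working notes on the imine variants of the shared core

The compounds below may be only part of what the source reports. "The series", "measured", "known", "first", "only" and "open" are said of these compounds alone.

In a functional assay on Ehrlich cells (Mus musculus) for cytotoxicity, read by trypan blue exclusion, with a stated time of 2 h, tested at 50 ug/mL (a higher number here means a stronger effect of the compound at the concentration tested, a lower number a weaker effect), compound 1 `N#CC1=C(NC(=O)C2CC2)N(c2ccc(S(N)(=O)=O)cc2)C2=C(C(=O)CCC2)C1c1ccc(Cl)cc1Cl` gives 40%. Compound 2 `CN(C)c1ccc(/C=C/C=N/C2=C(C#N)C(c3ccc(Cl)cc3Cl)C3=C(CCCC3=O)N2c2ccc(S(N)(=O)=O)cc2)cc1` gives 20% in this assay, and compound 3 `N#CC1=C(/N=C/c2ccc([N+](=O)[O-])cc2[N+](=O)[O-])N(c2ccc(S(N)(=O)=O)cc2)C2=C(C(=O)CCC2)C1c1ccc(Cl)cc1Cl` gives 20%. Compound 3 thus stands level with compound 2 at the digits shown; the two together are the lowest of the three numbers, and compound 1 lies higher than compound 3 by a margin beyond the scatter. For the measured compounds named here, the one step that can be read on the same carbon, no change at the digits printed from compound 2 to compound 3 (within the scatter), shows that exchanging the whole group on the carbon with a double bond to nitrogen left the read-out unchanged within the scatter.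

Compound 4 `CCO/C=N/C1=C(C#N)C(c2ccc(Cl)cc2Cl)C2=C(CCCC2=O)N1c1ccc(S(N)(=O)=O)cc1` has not yet been measured in this assay. Its change from compound 3 is ethoxy in place of 2,4-dinitrophenyl on a carbon with a double bond to nitrogen. The step from compound 2 to compound 3 is the only measured one at this place and it bears directly on the new change; it was flat. Compound 1 differs from compound 3 in a different way, through an amide rather than an imine, so its higher value is not a step of the same kind. The expectation for compound 4 is therefore a step of a number 2 percentage points higher from compound 3 to compound 4 (within the scatter), that is, no change beyond the scatter. Compound 4 is estimated at 22%, with a range of 10% to 40%.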

Compound 4, a percentage reported as activity, at one concentration (the size of the read-out at that concentration, not a potency): 35%
Estimate against measurement, compound 4: 13 percentage points below; low and high end bracket the measured number.
By their numbers in this assay, from the lowest: compounds 2 and 3 (each within the scatter of the next); then compounds 4 and 1 (each within the scatter of the next).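

In this assay the place on the carbon with a double bond to nitrogen no longer reads as flat: with ethoxy in place of 2,4-dinitrophenyl there is a number 15 percentage points higher from compound 3 to compound 4 (beyond the scatter) and with ethoxy in place of 2-(4-(dimethylamino)phenyl)ethenyl there is a number 15 percentage points higher from compound 2 to compound 4 (beyond the scatter) so the level reading of the two earlier imine variants does not extend to every group at this place. Ethoxy, which has no ring, is the only group of these three that moves the read-out beyond the scatter, though this rests on three compounds and a single ringless group. Against the amide of compound 1 the change gives a number 5 percentage points lower from compound 1 to compound 4 (within the scatter) and so, among the compounds shown, the gap between compound 1 and the lower variants does not simply separate an amide from everything carrying a carbon with a double bond to nitrogen.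

Going by these compounds, it remains open whether a methoxy group, a longer alkoxy chain or an amine on this same carbon would keep the read-out, and whether the oxygen or the absence of a ring goes with the step. Nothing available here accounts for the step in terms of a cause.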